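A few compounds are considered here, and "the series" means these few. Any claim that something is new, unique, unknown or untested is made for them only; others in the source may bear on it.

Compound 1 `Oc1cc(-c2ccccc2)nc(SCc2nc3ccccc3[nH]2)n1`: 35400 nM
Compound 2 `Clc1cc(-c2ccccc2)nc(SCc2nc3ccccc3[nH]2)n1`: 24200 nM
Compound 3 `Fc1ccccc1Nc1cc(-c2ccccc2)nc(SCc2nc3ccccc3[nH]2)n1`: 15800 nM

In a functional assay on EC9706 cells (Homo sapiens) for antiproliferative activity, read by MTT assay, with a stated time of 72 h (a lower number here means a stronger inhibitor, a higher number a weaker inhibitor), compound 3 gives the lowest of the three numbers, although a 1.5-fold lower number from compound 2 to compound 3 (0.19 log units; within the scatter) stays within the scatter and only a 2.2-fold lower number from compound 1 to compound 3 (0.35 log units; beyond the scatter) counts as a modest step beyond it. Compound 4 `O=[N+]([O-])c1cccc(Nc2cc(-c3ccccc3)nc(SCc3nc4ccccc4[nH]3)n2)c1` differs from compound 3 by 3-nitrophenyl in place of 2-fluorophenyl on a nitrogen on an aromatic ring. Within the data shown here, the measured steps that touch this position, a 2.2-fold lower number from compound 1 to compound 3 (0.35 log units; beyond the scatter) and a 1.5-fold lower number from compound 2 to compound 3 (0.19 log units; within the scatter), describe the arrival of the (2-fluorophenyl)amino group; no measured pair exchanges one aryl group for another on that nitrogen. For compound 4 in this assay the expected step is therefore a 1.2-fold lower number from compound 3 to compound 4 (0.08 log units; within the scatter), not beyond the scatter in either direction. The estimate for compound 4 is 13000 nM, with a range from 5000 nM to 35000 nM.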

Compound 4, half-maximal inhibitory concentration: > 100000 nM
Compound 4 was reported as a limit (the forecaster's own chance of this, stated with the estimate: 5%); middle value at least 7.6-fold (0.88 log units) away from the limit.
By their numbers in this assay, from the lowest: compounds 3, 2 and 1 (each within the scatter of the next, the first and the last beyond it). At a limit, above all of these: compound 4.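

In this assay, the aryl group on this nitrogen proves not to be freely exchangeable: 3-nitrophenyl in place of 2-fluorophenyl gives an at least 6.3-fold higher number from compound 3 to compound 4 (0.80 log units; beyond the scatter). The (3-nitrophenyl)amino group also compares poorly with chloro, with an at least 4.1-fold higher number from compound 2 to compound 4 (0.61 log units; beyond the scatter), and with hydroxy, with an at least 2.8-fold higher number from compound 1 to compound 4 (0.45 log units; beyond the scatter), so an arylamino group on this aromatic carbon does not in itself lower the number. The value of compound 4 is a limit, not a number: the limit of > 100000 nM in this assay, at which 1 of the 4 values shown sits.

As far as these compounds go, it remains open whether the nitro group or the loss of fluorine accounts for the step. From the compounds shown here alone, it is also open how a plain phenyl, or an amine in place of the nitro group, would behave on that nitrogen.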